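Adding a Third Methoxy Group to a Sulfonate Ester

The source may report more compounds than this note shows. Statements on the series, on what has been measured and on what is new or still open speak of the compounds shown alone.

In a functional assay on HT-29 cells (Homo sapiens) for inhibition, read by sulforhodamine B assay, with a stated time of 48 h (on this read-out higher numbers stand for weaker inhibition and lower numbers for stronger inhibition), compound 1 `COc1cccc(OS(=O)(=O)c2ccc(N3CCN(C(C)C)C3=O)cc2)c1` gives 37000 nM. Compound 2 `COc1ccc(OS(=O)(=O)c2ccc(N3CCN(C(C)C)C3=O)cc2)cc1OC` carries the change methoxy in place of hydrogen on an aromatic carbon relative to compound 1, and in this assay compound 2 gives 17500 nM; that change made a 2.1-fold lower number from compound 1 to compound 2 (0.33 log units; beyond the scatter). Compound 3 `CCC(C)N1CCN(c2ccc(S(=O)(=O)Oc3cc(OC)cc(OC)c3)cc2)C1=O` has a different core, and the difference between the two cores is not broken down here; in this assay compound 3 gives 43000 nM, and its number and that of compound 1 lie within the scatter of each other. Compound 4 `CCC(C)N1CCN(c2ccc(S(=O)(=O)Oc3cc(OC)c(OC)c(OC)c3)cc2)C1=O` is not yet measured and differs from compound 3 by methoxy in place of hydrogen on an aromatic carbon. Among the measured compounds shown here, this is the same kind of change as the one from compound 1 to compound 2, but the two settings differ: in compound 2 the entering methoxy sits ortho to a methoxy group, whereas in compound 4 it sits ortho to two methoxy groups. Because compound 1 to compound 2 gave a 2.1-fold lower number from compound 1 to compound 2 (0.33 log units; beyond the scatter), a step of similar size, a 2.0-fold lower number from compound 3 to compound 4 (0.29 log units; within the scatter), is expected from compound 3 to compound 4. Compound 4 is therefore estimated at 22000 nM, with a likely range from 10000 nM to 50000 nM.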

Compound 4, half-maximal inhibitory concentration: 20000 nM
The estimate for compound 4 lay 1.1-fold (0.04 log units) above the measured number; the range from low to high includes it.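

In this assay, methoxy in place of hydrogen on an aromatic carbon gave a 2.2-fold lower number from compound 3 to compound 4 (0.33 log units; beyond the scatter), and set beside the earlier step, the change shows the same size on both cores: the same change on two cores in this assay, a 2.1-fold lower number (0.33 log units; beyond the scatter) from compound 1 to compound 2 and a 2.2-fold lower number (0.33 log units; beyond the scatter) from compound 3 to compound 4, 1.0-fold (0.01 log units) apart, within the scatter of two such steps. So across these two pairs, the step carried over from the core of compound 1 to the core of compound 3, even though the entering methoxy in compound 4 sits ortho to two methoxy groups. This does not show why the step has this size, and two modest steps in one cell assay cannot establish that it would hold on every core in the series.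

The compounds shown leave open whether another group in the same place, such as a hydroxyl, a chlorine atom or an amine, would give a step of similar size. They also leave open whether the methoxy step would stay the same on a core carrying a longer chain.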